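A Thiophene for a Chlorophenyl: Expected Cytotoxicity of Compound 4

The source may report more compounds than this note shows. Statements on the series, on what has been measured and on what is new or still open speak of the compounds shown alone.

Of the compounds shown here, three sharing one core have been tested in an ADME assay on L929 cells (Mus musculus) for cytotoxicity, read by resazurin assay, with a stated time of 72 h; a higher number here means a weaker inhibitor, a lower number a stronger inhibitor. Compound 1 `OB1OCc2ccc(-n3ccc4ccccc43)cc21` gives > 10 ug/mL in this assay, which is a limit of the assay rather than a measured number. Compound 2 `O=C(NC1CCCCC1)c1cccn1-c1ccc2c(c1)B(O)OC2` gives > 10 ug/mL in this assay, again only a limit. Compound 3 `O=C(c1ccc(Cl)cc1)c1ccn(-c2ccc3c(c2)B(O)OC3)c1` gives > 10 ug/mL in this assay, also a limit. Among the measured compounds shown here, compound 3 therefore stands at the limit of > 10 ug/mL in this assay, at which 3 of the 3 values shown sit, and none of the measured compounds is separated from it by a known number. For the measured compounds named here, no step between two measured compounds is available, so nothing in these data shows how a change of the kind below moves the read-out.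

Compound 4 `O=C(c1ccn(-c2ccc3c(c2)B(O)OC3)c1)c1cccs1` has not been measured yet. It differs from compound 3 in one place: thiophen-2-yl in place of 4-chlorophenyl on a carbonyl carbon.

Since compound 3 and both other compounds sit at the limit of > 10 ug/mL in this assay, at which 3 of the 3 values shown sit, the expected step in this assay is none beyond the scatter, and the estimated change is a step that the limit leaves unreadable from compound 3 to compound 4. Compound 4 is accordingly expected to give about 15 ug/mL in this assay, within an estimated range from 7 ug/mL to 40 ug/mL, and the assay will most likely report only a limit once more.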

Compound 4, half-maximal inhibitory concentration: > 10 ug/mL
Compound 4: a limit, no number; the forecaster's own chance of this, stated with the estimate: 85%; the middle value is on the limit's open side.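

Compound 3 and compound 4 both give only a limit rather than a number, so no step between them can be read in this assay: the limit of > 10 ug/mL in this assay, at which 4 of the 4 values shown sit.

The compounds shown leave open where the true value of any of them lies, and whether thiophen-2-yl in place of 4-chlorophenyl on a carbonyl carbon shifts the read-out at all.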